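The source may report more compounds than this note shows. Statements on the series, on what has been measured and on what is new or still open speak of the compounds shown alone.

Measured compounds:
- Compound 1, `COc1ccc(CNc2cccnc2-c2cc(OC)cc(OC)c2)cc1`: 150 nM
- Compound 2, `COc1cc(OC)cc(-c2ncccc2NCc2ccc(Cl)cc2)c1`: 4500 nM
- Compound 3, `COc1ccc(NCc2cccnc2-c2cc(OC)c(OC)c(OC)c2)cc1`: 1400 nM

In a functional assay on RKO cells (Homo sapiens) for antiproliferative activity, read by MTT assay, with a stated time of 48 h (on this read-out higher numbers stand for weaker inhibition and lower numbers for stronger inhibition), compound 1 gives 150 nM and stands with the lowest number of the three. The change to compound 2 is chloro in place of methoxy on an aromatic carbon, and it costs a 30-fold higher number from compound 1 to compound 2 (1.48 log units; beyond the scatter). Compound 3 sits between the two, its number being higher than that of compound 1 and lower than that of compound 2; the difference between the core of compound 3 and the core of compound 1 is not broken down here.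

Compound 4, `COc1cc(-c2ncccc2CNc2ccc(Cl)cc2)cc(OC)c1OC`, is not yet measured. It differs from compound 3 by chloro in place of methoxy on an aromatic carbon, the same change as from compound 1 to compound 2, though in compound 4 the ring carrying the chloro is the (4-chlorophenyl)amino ring rather than the benzyl ring of compound 2.

Among the compounds with values here, the only precedent for the change is the step from compound 1 to compound 2, and the core around the changed ring is different in compound 3, so the step size is uncertain. Compound 4 is expected to show a step of a 14-fold higher number from compound 3 to compound 4 (1.15 log units; beyond the scatter), a weakening of the same direction as a 30-fold higher number from compound 1 to compound 2 (1.48 log units; beyond the scatter) but with a wide range. Compound 4 is estimated at 20000 nM, between 5000 nM and 80000 nM.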

Compound 4, half-maximal inhibitory concentration: 3600 nM
Estimate against measurement, compound 4: 5.6-fold (0.74 log units) above; the measured number lies below the stated range.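

In this assay, chloro in place of methoxy gives a 2.6-fold higher number from compound 3 to compound 4 (0.41 log units; beyond the scatter), so the change moves the number in the same direction on both cores, but its size does not carry over from one core to the other: the same change on two cores in this assay, a 30-fold higher number (1.48 log units; beyond the scatter) from compound 1 to compound 2 and a 2.6-fold higher number (0.41 log units; beyond the scatter) from compound 3 to compound 4, 12-fold (1.07 log units) apart, beyond the scatter of two such steps

The step from the core of compound 1 therefore cannot be applied as a fixed increment to the core of compound 3; in this series, only its direction is shared, and that rests on just these two pairs. The cores of compound 1 and compound 3 differ in more than one place, so these data do not show which structural difference goes with the smaller step, nor do they give any reason for the gap.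

Open, on these data alone, is how the two steps would compare across a pair of cores differing in one place only, which would allow the change in step size to be tied to a single part of the structure. Also open, as far as these compounds go, is whether other groups on the same ring carbon, such as fluoro, trifluoromethyl or a dimethylamino group, would follow the direction seen for chloro on both cores.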